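This account rests on a few compounds, and the source may have more. Where it says the series, first, only, none or still open, it means among the compounds named here.

Working notes on the series. In a toxicity assay on HT-29 cells (Homo sapiens) for cytotoxicity (on this read-out higher numbers stand for lower toxicity in this test and lower numbers for higher toxicity in this test), compound 1 `COCCn1nc(C(=O)N[C@H]2COc3ccccc3N(C)C2=S)nc1Cc1ccccc1` gives > 100000 nM, a limit of the assay and not a number. Compound 2 `CN1C(=S)[C@@H](NC(=O)c2nc(Cc3ccccc3)n(C3CCNC3)n2)COc2ccccc21` gives > 100000 nM, likewise a limit and not a number. Compound 2 therefore has no numerical position in the series, and the record so far is the limit of > 100000 nM in this assay, at which 2 of the 2 values shown sit.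

Compound 3 `CN1C(=S)[C@@H](NC(=O)c2nc(Cc3ccccc3)n(C3CCNCC3)n2)COc2ccccc21` keeps the shared core and carries piperidin-4-yl in place of pyrrolidin-3-yl on an aromatic nitrogen of the five-membered aromatic ring with 3 nitrogen (piperidin-4-yl in place of pyrrolidin-3-yl on an aromatic nitrogen). Going by the values given here, the one measured step at this aromatic nitrogen is a step that the two limits leave unreadable from compound 1 to compound 2, with pyrrolidin-3-yl in place of 2-methoxyethyl. It bears directly on the change but offers no size to carry forward. Resting on that step of compound 2 a step that the two limits leave unreadable from compound 1 to compound 2, no shift beyond the scatter and no direction are expected in this assay. The expected change is a number no higher from compound 2 to compound 3 (the limit leaves the size open), and a report of compound 3 as a limit again is the likeliest outcome. For compound 3 the estimated value is 100000 nM, with an expected range from 50000 nM to 200000 nM.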

Compound 3, half-maximal cytotoxic concentration: > 100000 nM
Compound 3: only a limit was reported; the forecaster's own chance of this, stated with the estimate: 90%; the middle value sits exactly at the limit.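

In this assay compound 3 gives > 100000 nM, a limit and not a number. Going by these compounds alone, no step among compound 1, compound 2 and compound 3 can therefore be read. The compounds shown leave open whether any group on the aromatic nitrogen shifts this read-out, as the record stands at one limit: the limit of > 100000 nM in this assay, at which 3 of the 3 values shown sit.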